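Methylating the ring amide nitrogen in a chlorinated spiro series

This account rests on a few compounds, and the source may have more. Where it says the series, first, only, none or still open, it means among the compounds named here.

Compound 1, `CN1C/C(=C\c2ccccc2)C(=O)[C@]2(C1)[C@@H](c1ccccc1)CN(C)[C@@]21C(=O)Nc2ccccc21`, was tested in a functional assay on the whole organism (strain Wister albino) for inhibition, with Rattus norvegicus as the target, read by paw edema, with stated times of 1 h and 4 h, at a dose of 50 mg/kg by the intraperitoneal route (a higher number here means more inhibition at the dose given (going by the name of the read-out), a lower number less inhibition), where compound 1 gives 70.9%. Compound 2, `CN1C/C(=C\c2ccccc2)C(=O)[C@]2(C1)[C@@H](c1ccccc1)CN(C)[C@@]21C(=O)N(C)c2ccccc21`, differs from compound 1 by one change, (methyl in place of hydrogen on an amide-type nitrogen in a ring), and in this assay compound 2 gives 68.8%. That change made a step of a number 2.1 percentage points lower from compound 1 to compound 2 (within the scatter).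

Compound 3, `CN1C/C(=C\c2ccc(Cl)cc2)C(=O)[C@]2(C1)[C@@H](c1ccc(Cl)cc1)CN(C)[C@@]21C(=O)Nc2ccccc21`, carries a different core; how its core differs from that of compound 1 is not broken down here. In this assay compound 3 gives 42.2%, the lowest of the three numbers, and its gap to compound 1 and to compound 2 lies beyond the scatter.

Compound 4, `CN1C/C(=C\c2ccc(Cl)cc2)C(=O)[C@]2(C1)[C@@H](c1ccc(Cl)cc1)CN(C)[C@@]21C(=O)N(C)c2ccccc21`, has not yet been measured. It differs from compound 3 by methyl in place of hydrogen on an amide-type nitrogen in a ring, the same change that was made from compound 1 to compound 2, and it occurs twice among these compounds. From compound 3 to compound 4 a step of about a number 2.2 percentage points lower from compound 3 to compound 4 (within the scatter) is expected in this assay, because the earlier step of a number 2.1 percentage points lower from compound 1 to compound 2 (within the scatter) was small. Compound 4 is therefore estimated to give around 40% in this assay, expected to fall between 30% and 52%.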

Compound 4, a percentage reported as inhibition, in the whole organism at one dose (the size of the read-out at that dose, not a potency): 45.7%
For compound 4 the middle estimate is 5.7 percentage points below the measured one; the measured number falls inside the stated range.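

In this assay, methyl in place of hydrogen on the amide-type nitrogen again gave only a small step on the core of compound 3, with a number 3.5 percentage points higher from compound 3 to compound 4 (within the scatter). Set beside the earlier step on the core of compound 1, the two results agree, so in these two cases the change carried from one core to the other without a step that stands out from the scatter: the same change on two cores in this assay, a number 2.1 percentage points lower (within the scatter) from compound 1 to compound 2 and a number 3.5 percentage points higher (within the scatter) from compound 3 to compound 4, 5.6 percentage points apart, within the scatter of two such steps. This does not prove that the methyl has no effect or that it acts in opposite directions on the two cores, and two cores tested at a single dose cannot establish a rule for the whole series.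

The compounds shown leave open whether an ethyl group, a longer chain or a benzyl group on that same nitrogen would also leave the number within the scatter. They also leave open whether the methyl step would stay this small on a core carrying methoxy groups in place of the chlorine atoms.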